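The source may report more compounds than this note shows. Statements on the series, on what has been measured and on what is new or still open speak of the compounds shown alone.

Compound 1 `Cc1nc(C(F)(F)F)ccc1C(=O)Nc1ccc(Cl)c(-c2nc3ccccc3[nH]2)c1` and compound 2 `Cc1nc(C(F)(F)F)ccc1C(=O)Nc1ccc(Cl)c(-c2cn3ccsc3n2)c1` share one core and differ only in the aromatic group attached to the chlorinated ring. In an assay on C3H 10T1/2 cells for inhibition of Sonic hedgehog protein (Mus musculus), read by a luciferase reporter (on this read-out higher numbers stand for weaker inhibition and lower numbers for stronger inhibition), compound 1 gives 12 nM, and in this assay compound 2 gives 200 nM. For the measured compounds named here, compound 2 therefore stands at the highest of the two numbers, with the single measured step, a 17-fold higher number from compound 1 to compound 2 (1.22 log units; beyond the scatter), lying well beyond the scatter. Compound 3 `Cc1nc(C(F)(F)F)ccc1C(=O)Nc1ccc(Cl)c(-c2cccnc2)c1` keeps everything else and differs from compound 2 in one place: a group of 6 heavy atoms (5 carbon, 1 nitrogen; one six-membered aromatic ring with 1 hetero atom) in place of a group of 8 heavy atoms (5 carbon, 2 nitrogen, 1 sulfur; 2 five-membered aromatic rings with 2 hetero atoms each), on an aromatic carbon. Going by the values given here, no measured step covers this particular exchange. Among the compounds with values here, the step from compound 1 to compound 2 shows only that changing the group on this carbon can shift the number strongly, so a sizeable move in either direction is possible. The step in this assay is expected to be a 3.3-fold lower number from compound 2 to compound 3 (0.52 log units; beyond the scatter), a modest improvement. Compound 3 is therefore estimated at 60 nM, within a range from 15 nM to 300 nM.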

Compound 3, half-maximal inhibitory concentration: 10000 nM
Compound 3: the middle estimate sits 170-fold (2.22 log units) below what was measured, and the stated range ends below it.
By their numbers in this assay, from the lowest: compound 1; then compound 2; then compound 3.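

In this assay the exchange for pyridin-3-yl gives a 50-fold higher number from compound 2 to compound 3 (1.70 log units; beyond the scatter) on this aromatic carbon, ortho to a chloro group, so the group of two five-membered aromatic rings, though the weaker of the earlier pair, still stands far ahead of this single ring. Starting from 1H-benzimidazol-2-yl, the same exchange gives an 830-fold higher number from compound 1 to compound 3 (2.92 log units; beyond the scatter) and shows how widely the number moves with the group at this one place: among these three compounds, both two-ring groups give lower numbers than the single ring. No evidence at hand accounts for these differences.

The compounds shown do not separate the effect of having one ring from that of the particular ring chosen. From the compounds shown here alone, how phenyl, pyridin-2-yl, or a pyridin-3-yl carrying an amine or a methoxy group would read in this assay stays open.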